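Para-Substituent Swap on an Alpha-Methylene Lactone Core

The source may report more compounds than this note shows. Statements on the series, on what has been measured and on what is new or still open speak of the compounds shown alone.

Measured compounds and their values:
Compound 1 `C=C1C(=O)ON(C)C1C(C)C` – 2630 nM
Compound 2 `C=C1C(=O)ON(C)C1c1ccccc1` – 5500 nM
Compound 3 `C=C1C(=O)ON(C)C1c1ccc(C)cc1` – 800 nM

In a functional assay on L1210 cells (Mus musculus) for antiproliferative activity (on this read-out higher numbers stand for weaker inhibition and lower numbers for stronger inhibition), compound 3 gives the lowest of the three numbers. Compound 1 sits a step above it, and compound 2 is furthest away. Among the compounds with values here, the only single-point change among the measured compounds is the one a 6.9-fold lower number from compound 2 to compound 3 (0.84 log units; beyond the scatter), which is a modest step that clears the scatter.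

Compound 4 `C=C1C(=O)ON(C)C1c1ccc(OC)cc1` differs from compound 3 in one place: methoxy in place of methyl on an aromatic carbon. Within the data shown here, no measured pair shows a methoxy against a methyl on the aromatic ring, so the one available step bears on this change only indirectly: it shows that a small group on that aromatic carbon, compared with hydrogen, lowers the number in this assay. Whether an oxygen-bearing group of similar size keeps that gain is not shown by the data. A step from compound 3 to compound 4 of a size within the scatter, in either direction, is therefore expected.

The number for compound 4 is estimated at 1000 nM, with a range from 350 nM to 3000 nM, meaning an expected step of a 1.3-fold higher number from compound 3 to compound 4 (0.10 log units; within the scatter).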

Compound 4, half-maximal inhibitory concentration: 3500 nM
Estimate against measurement, compound 4: 3.5-fold (0.54 log units) below; measured number outside the range, above it.
By their numbers in this assay, from the lowest: compound 3; then compounds 1, 4 and 2 (each within the scatter of the next, the first and the last beyond it).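

In this assay, the result shows that this aromatic carbon responds to which group it carries and not merely to hydrogen being replaced: a 4.4-fold higher number from compound 3 to compound 4 (0.64 log units; beyond the scatter), a change beyond the scatter for a swap of methyl for methoxy. Against hydrogen on the same carbon, a 1.6-fold lower number from compound 2 to compound 4 (0.20 log units; within the scatter), which lies within the scatter, so methoxy does not keep the gain that methyl gave in a 6.9-fold lower number from compound 2 to compound 3 (0.84 log units; beyond the scatter). Among the compounds shown, the lower number on this carbon therefore belongs to methyl alone, and nothing available accounts for the difference between the two groups.

The compounds shown leave open where a chlorine, a hydroxyl or an amine on this aromatic carbon would fall relative to methyl and methoxy. They also leave open whether the gain seen with methyl extends to a longer chain such as ethyl, or whether it is confined to the single carbon of the methyl group.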